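The source may report more compounds than this note shows. Statements on the series, on what has been measured and on what is new or still open speak of the compounds shown alone.

Going by the values given here, compound 3 `Cc1ccc(C(=O)c2cc(Cl)ccc2Oc2cc(C)nc(Nc3ccc(C#N)cc3)n2)cc1` gives 26600 nM in an ADME assay on MT4 cells (Homo sapiens) for cytotoxicity, read by MTT assay, with a stated time of 5 days (on this read-out lower numbers stand for higher toxicity in this test and higher numbers for lower toxicity in this test), and stands second highest of the three numbers measured so far; compound 2 `Cc1cc(C)cc(C(=O)c2cc(Cl)ccc2Oc2ccnc(Nc3ccc(C#N)cc3)n2)c1` gives 28800 nM, which lies within the scatter of compound 3, while compound 1 `Cc1ccc(C(=O)c2cc(Cl)ccc2Oc2ccnc(Nc3ccc(C#N)cc3)n2)cc1` gives 1710 nM, a gap beyond the scatter, as a 16-fold higher number from compound 1 to compound 3 (1.19 log units; beyond the scatter) shows. Compound 4 `Cc1cc(C)cc(C(=O)c2cc(Cl)ccc2Oc2cc(C)nc(Nc3ccc(C#N)cc3)n2)c1` differs from compound 3 by 3,5-dimethylphenyl in place of 4-methylphenyl on a carbonyl carbon. The same change has been seen once in the series: a 17-fold higher number from compound 1 to compound 2 (1.23 log units; beyond the scatter). Among the compounds with values here, both single changes on compound 1 raised the number by a similar amount, and no measured pair shows how the two combine. Within the data shown here, a further rise in this assay is expected for compound 4, likely smaller than the single step, with a 2.3-fold higher number from compound 3 to compound 4 (0.35 log units; beyond the scatter) as the estimated step. Compound 4 is estimated at 60000 nM, with a range from 25000 nM to 150000 nM.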

Compound 4, half-maximal cytotoxic concentration: 37100 nM
For compound 4 the middle estimate is 1.6-fold (0.21 log units) above the measured one; measured number inside the range.
By their numbers in this assay, from the lowest: compound 1; then compounds 3, 2 and 4 (each within the scatter of the next).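

With the methyl already on the aromatic carbon, 3,5-dimethylphenyl in place of 4-methylphenyl on a carbonyl carbon gives a 1.4-fold higher number from compound 3 to compound 4 (0.14 log units; within the scatter) in this assay, so the large step does not carry over to that core: the same change on two cores in this assay, a 17-fold higher number (1.23 log units; beyond the scatter) from compound 1 to compound 2 and a 1.4-fold higher number (0.14 log units; within the scatter) from compound 3 to compound 4, 12-fold (1.08 log units) apart, beyond the scatter of two such steps

Likewise, with 3,5-dimethylphenyl in place, methyl in place of hydrogen on an aromatic carbon gives a 1.3-fold higher number from compound 2 to compound 4 (0.11 log units; within the scatter): the same change on two cores in this assay, a 16-fold higher number (1.19 log units; beyond the scatter) from compound 1 to compound 3 and a 1.3-fold higher number (0.11 log units; within the scatter) from compound 2 to compound 4, 12-fold (1.08 log units) apart, beyond the scatter of two such steps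

The two changes therefore do not add: once either is present, the step from the other stays within the scatter.

The compounds shown leave open whether an amine or a longer chain in place of that methyl would behave the same way.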